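The compounds below may be only part of what the source reports. "The series", "measured", "known", "first", "only" and "open" are said of these compounds alone.

Measured compounds in an assay on cells with melanin-concentrating hormone receptor 1 (Homo sapiens) as the target, read by radioligand binding; on this read-out lower numbers stand for stronger inhibition and higher numbers for weaker inhibition:
compound 1 `CCOCCOc1cccc2ccc(N)nc12`, > 2000 nM, a limit of the assay
compound 2 `CC(C)OCCOc1cccc2ccc(N)nc12`, > 2000 nM, a limit of the assay
compound 3 `CCC#CCOc1cccc2ccc(N)nc12`, > 2000 nM, a limit of the assay

Compound 1 thus stands only at a limit, with no number of its own. The step that the two limits leave unreadable from compound 1 to compound 2 and the step that the two limits leave unreadable from compound 1 to compound 3 cannot be read, since (the limit of > 2000 nM in this assay, at which 3 of the 3 values shown sit). Compound 4 `COC(C)(C)CCOc1cccc2ccc(N)nc12` carries the change (1-methoxy-1-methylethyl in place of ethoxy on a saturated chain carbon, two bonds along the chain from an oxygen on an aromatic ring). Within the data shown here, no measured step resolves a change of this kind, and all three measured values sit at the same limit, so no direction can be drawn. The expectation for compound 4 is therefore a step that the limit leaves unreadable from compound 1 to compound 4 in this assay , most likely again only a limit. Compound 4 is estimated at 3500 nM, between 1500 nM and 10000 nM.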

Compound 4, half-maximal inhibitory concentration: 132 nM
Beside the measured number, compound 4's estimate is 27-fold (1.42 log units) above it; the whole stated range lies above it.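

In this assay, among these compounds, 1-methoxy-1-methylethyl at this place, on a saturated chain carbon, two bonds along the chain from an oxygen on an aromatic ring, gives the first readable steps: an at least 15-fold lower number from compound 1 to compound 4 (1.18 log units; beyond the scatter), an at least 15-fold lower number from compound 2 to compound 4 (1.18 log units; beyond the scatter), and an at least 15-fold lower number from compound 3 to compound 4 (1.18 log units; beyond the scatter). An oxygen in the chain is not enough by itself: compound 1 and compound 2 also hold one, yet each sits only at a limit. The steps among compound 1, compound 2 and compound 3 cannot be read: the limit of > 2000 nM in this assay, at which 3 of the 4 values shown sit.

The compounds shown do not separate the methoxy from the two methyl groups of the entering group. As far as these compounds go, how a tert-butyl group, an amine or a longer chain at this place would read also stays open.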